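The source may report more compounds than this note shows. Statements on the series, on what has been measured and on what is new or still open speak of the compounds shown alone.

Measured so far in a functional assay on HEK293 cells for agonist activity at probable G-protein coupled receptor 27 (Homo sapiens), read by a luciferase reporter and beta-arrestin recruitment, with a stated time of 10 min; on this read-out lower numbers stand for smaller maximal responses and higher numbers for larger maximal responses:

Compound 1, `CN(c1ccccc1)S(=O)(=O)c1ccc(NC(=O)c2ccc(Cl)cc2Cl)cc1`: 50%
Compound 2, `O=C(Nc1ccc(S(=O)(=O)Nc2ccccc2)cc1)c1cc2ccccc2oc1=O`: 53%
Compound 3, `O=C(Nc1ccc(S(=O)(=O)Nc2ccccc2)cc1)c1ccc(Br)cc1F`: 67%

Among these three, compound 3 gives the highest maximal response. Its gaps to compound 2 and to compound 1 both lie beyond the usual scatter of repeated measurements, so compound 3 can be called the strongest of the three on this read-out.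

The next compound, compound 4, `Cc1cc(Cl)ccc1C(=O)Nc1ccc(S(=O)(=O)Nc2ccccc2)cc1`, keeps the shared core of compound 3 and changes only the group on the carbonyl carbon:

4-chloro-2-methylphenyl in place of 4-bromo-2-fluorophenyl on a carbonyl carbon

For the measured compounds named here, no step between two measured compounds that differ in a single place has been recorded, so there is no direct precedent for how this assay reacts to such a swap. The replacement keeps the size of the group and its ring, and changes only which atoms sit on it. A step from compound 3 to compound 4 of about the size of the scatter, slightly downward, is expected: a number 7 percentage points lower from compound 3 to compound 4 (within the scatter). For compound 4 the estimated maximal response is 60%, with a range from 45% to 75%.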

Compound 4, largest response reached (Emax), in percent of the reference or control that the assay uses: 123%
For compound 4 the middle estimate is 63 percentage points below the measured one, and the stated range ends below it.
By their numbers in this assay, from the lowest: compounds 1 and 2 (each within the scatter of the next); then compound 3; then compound 4.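

In this assay, putting 4-chloro-2-methylphenyl in place of 4-bromo-2-fluorophenyl on the carbonyl carbon gives a number 56 percentage points higher from compound 3 to compound 4 (beyond the scatter), and compound 4, at 123%, exceeds the full response of the reference or control used by the assay. The maximal response is therefore highly sensitive to what this ring carries, even though both groups have the same count of heavy atoms, the same carbon-only aromatic ring, no hydrogen-bond donors or acceptors and no net charge. No measurement at hand explains the size of this step.

The swap changes two things at once, bromine to chlorine and fluorine to methyl, so the compounds shown cannot say which of them carries the step. They also leave open how the response changes with an amine or a carboxylic acid on this ring.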